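Furan in Place of Methoxyphenyl on the Enone Chain

A few compounds are considered here, and "the series" means these few. Any claim that something is new, unique, unknown or untested is made for them only; others in the source may bear on it.

Compound 1: `Cc1nc(NC(=O)c2ccccc2)sc1C(=O)/C=C/c1cccc(Br)c1`, 42.5%
Compound 2: `Cc1nc(NC(=O)c2ccccc2)sc1C(=O)/C=C/c1cccc([N+](=O)[O-])c1`, 98%
Compound 3: `COc1ccc(/C=C/C(=O)c2sc(NC(=O)c3ccccc3)nc2C)cc1`, 58.8%

Of the compounds shown here, three sharing one core have been measured in an assay for inhibition of Polyunsaturated fatty acid 5-lipoxygenase (Homo sapiens), read by spectrophotometry, tested at 10 uM, in the presence of a further agent that is not named here (a higher number here means more inhibition at the concentration tested (going by the name of the read-out), a lower number less inhibition), and all three vary only in the aryl group on the double-bonded chain carbon. Compound 3 stands second highest of the three: compound 2 lies above it by a number 39.2 percentage points lower from compound 2 to compound 3 (beyond the scatter) in the reverse sense, and compound 1 lies below it by a number 16.3 percentage points higher from compound 1 to compound 3 (beyond the scatter). Between compound 1 and compound 2 the gap is a number 55.5 percentage points higher from compound 1 to compound 2 (beyond the scatter).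

Compound 4, `Cc1nc(NC(=O)c2ccccc2)sc1C(=O)/C=C/c1ccco1`, has not been measured. It differs from compound 3 as follows: furan-2-yl in place of 4-methoxyphenyl on a double-bonded chain carbon bound to a double-bonded chain carbon. Within the data shown here, the two measured steps that touch this position, from compound 1 to compound 3 and from compound 2 to compound 3, show that the group on this carbon shifts the read-out in this assay by modest to large amounts, but none of them replaces a six-membered ring with a five-membered one, so no direct analogue exists. The account therefore expects a change of modest size, leaning downward, with a step of a number 10.8 percentage points lower from compound 3 to compound 4 (beyond the scatter) from compound 3 to compound 4. Compound 4 is estimated at 48%, within a range from 22% to 78%.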

Compound 4, a percentage reported as inhibition, at one concentration (the size of the read-out at that concentration, not a potency): 57.2%
Compound 4: middle estimate off by 9.2 percentage points, on the low side, and the stated range covers the measured number.
By their numbers in this assay, from the lowest: compound 1; then compounds 4 and 3 (each within the scatter of the next); then compound 2.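

In this assay, replacing 4-methoxyphenyl with the smaller furan-2-yl gives a number 1.6 percentage points lower from compound 3 to compound 4 (within the scatter), so at this position a five-membered aromatic ring with fewer heavy atoms reads the same as the six-membered one within the scatter. Compound 4 also stands apart from the other two compounds, with a number 14.7 percentage points higher from compound 1 to compound 4 (beyond the scatter) and a number 40.8 percentage points lower from compound 2 to compound 4 (beyond the scatter), so among these four compounds the two aryl groups that differ from the rest beyond the scatter are 3-bromophenyl and 3-nitrophenyl. Nothing available explains these readings.

On these data alone, it remains open whether a phenyl ring carrying an amine or a carboxylic acid at this carbon would give a reading closer to that of compound 2 or to those of compound 3 and compound 4. The compounds shown also leave open whether 4-nitrophenyl would read like 3-nitrophenyl.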